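This account rests on a few compounds, and the source may have more. Where it says the series, first, only, none or still open, it means among the compounds named here.

Three compounds share one core. Compound 1 `CCNC(=O)C1=C(C)NC(=O)NC1c1cccs1` gives 4% in an assay on membranes from HeLa cells for displacement of a labelled ligand from adenosine receptor A3 (Homo sapiens), read by scintillation counting, with a stated time of 180 min, tested at 1 uM (on this read-out higher numbers stand for more inhibition at the one concentration tested (going by the name of the read-out) and lower numbers for less inhibition), compound 2 `CC1=C(C(=O)OC2CCC2)C(c2cccs2)NC(=O)N1` gives 2% in this assay, and compound 3 `CC1=C(C(=O)OCC2CC2)C(c2cccs2)NC(=O)N1` gives 1% in this assay. Compound 3 holds the lowest of the three numbers, yet the steps of a number 1 percentage points lower from compound 2 to compound 3 (within the scatter) and a number 3 percentage points lower from compound 1 to compound 3 (within the scatter) both lie within the scatter, so no order among the three can be read. Compound 4 `CC1=C(C(=O)OCC2CCC2)C(c2cccs2)NC(=O)N1` differs from compound 3 by cyclobutyl in place of cyclopropyl on a saturated chain carbon bound to an oxygen next to a carbonyl group. The measured step that bears on this change is a number 1 percentage points lower from compound 2 to compound 3 (within the scatter), which also swapped small rings at the same place; a number 2 percentage points lower from compound 1 to compound 2 (within the scatter) was equally small. The expected step is therefore a number 1 percentage points higher from compound 3 to compound 4 (within the scatter), none beyond the scatter. Compound 4 is estimated at 2%, with a range from -5% to 10%.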

Compound 4, a percentage reported as inhibition, at one concentration (the size of the read-out at that concentration, not a potency): 1%
The estimate for compound 4 lay 1 percentage points above the measured number, within the range that was stated.
By their numbers in this assay, from the lowest: compounds 3, 4, 2 and 1 (each within the scatter of the next).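

In this assay the change of ring at the saturated chain carbon bound to an oxygen next to a carbonyl group gives no change at the digits printed from compound 3 to compound 4 (within the scatter), so cyclobutyl and cyclopropyl cannot be told apart at this place. The other two new steps, a number 1 percentage points lower from compound 2 to compound 4 (within the scatter) and a number 3 percentage points lower from compound 1 to compound 4 (within the scatter), add cyclobutylmethyl as a further group that stays within the scatter of the others. No evidence is available to explain these numbers. As far as these compounds go, whether an amine, a carboxylic acid or a longer chain at this place would give a step beyond the scatter remains open.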